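The source may report more compounds than this note shows. Statements on the series, on what has been measured and on what is new or still open speak of the compounds shown alone.

Compound 1 `COC(=O)CCCNC(=O)c1cc(C)cc2c1NC(C)(C)C=C2C`: > 30000 nM
Compound 2 `COC(=O)/C=C/CNC(=O)c1cccc2c1NC(C)(C)C=C2C`: 6700 nM

Both readings come from an ADME assay on Vero C1008 cells (Chlorocebus sabaeus) for cytotoxicity; on this read-out lower numbers stand for higher toxicity in this test and higher numbers for lower toxicity in this test. For compound 1, the reading of > 30000 nM is a limit of the assay and not a number. Within the data shown here, compound 2, at 6700 nM, therefore holds the only actual number so far, so it cannot yet be ranked by a measured step.

Compound 3 `COC(=O)CCCNC(=O)c1cccc2c1NC(C)(C)C=C2C` follows from compound 2 by one change: 2-(methoxycarbonyl)ethyl in place of 2-(methoxycarbonyl)ethenyl on a saturated chain carbon bound to an amide-type nitrogen. It has 2-(methoxycarbonyl)ethyl in place of 2-(methoxycarbonyl)ethenyl on a saturated chain carbon bound to an amide-type nitrogen. Compound 1 also carries the 3-(methoxycarbonyl)propyl chain, and its reading of > 30000 nM is a limit. Among the measured compounds shown here, no measured step supports the size, so a moderate rise towards lower toxicity in this test is only expected, with the estimated step being a 2.7-fold higher number from compound 2 to compound 3 (0.43 log units; beyond the scatter). Compound 3 is estimated at 18000 nM, with an expected range of 7000 nM to 40000 nM.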

Compound 3, half-maximal cytotoxic concentration: > 30000 nM
Compound 3: a limit, no number (the forecaster's own chance of this, stated with the estimate: 45%); middle value at least 1.6-fold (0.22 log units) from the limit.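

In this assay the chain position, on a saturated chain carbon bound to an amide-type nitrogen, gives its first readable step: 2-(methoxycarbonyl)ethyl in place of 2-(methoxycarbonyl)ethenyl gives an at least 4.4-fold higher number from compound 2 to compound 3 (0.65 log units; beyond the scatter) with the rest of the molecule unchanged. Compound 3 at > 30000 nM is a limit of the assay and not a number. The step therefore has a lower bound only, and its full size stays unknown because the readings stop at the same point: the limit of > 30000 nM in this assay, at which 2 of the 3 values shown sit.

The step for hydrogen in place of methyl on the aromatic carbon cannot be read, since compounds 1 and 3 are both limits. Still open, on these data alone, is whether a carboxylic acid in place of the methyl ester, or a longer chain, stays at this limit or gives a measurable number.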